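The compounds below may be only part of what the source reports. "The series", "measured", "known", "first", "only" and "open" are said of these compounds alone.

- Compound 1 `CCCCCCCCCCCC[C@@H](O)[C@H]1CC[C@H]([C@H](O)CCCCCCCCCCNC(=O)c2ccoc2)O1`: 100000 nM
- Compound 2 `CCCCCCCCCCCC[C@@H](O)[C@H]1CC[C@H]([C@H](O)CCCCCCCCCCNC(=O)c2cncs2)O1`: 100000 nM
- Compound 3 `CCCCCCCCCCCC[C@@H](O)[C@H]1CC[C@H]([C@H](O)CCCCCCCCCCNC(=O)c2ccsc2)O1`: 100000 nM

These three values all come from a functional assay on U-251 cells (Homo sapiens) for inhibition, read by colorimetric assay and sulforhodamine B assay, with a stated time of 48 h; a lower number here means a stronger inhibitor of growth, a higher number a weaker inhibitor of growth. Compound 1 stands level with compound 2 and compound 3, and the numbers do not separate the three.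

Compound 4 `CCCCCCCCCCCC[C@@H](O)[C@H]1CC[C@H]([C@H](O)CCCCCCCCCCNC(=O)c2ccnn2C)O1` keeps the core of compound 1 and changes only the ring on the amide: 1-methyl-1H-pyrazol-5-yl in place of furan-3-yl on a carbonyl carbon. In words, 1-methyl-1H-pyrazol-5-yl sits in place of furan-3-yl on a carbonyl carbon.

Within the data shown here, three measured steps bear on this change, since each swaps one five-membered aromatic ring for another at that same place: no change at the digits printed from compound 1 to compound 2 (within the scatter), no change at the digits printed from compound 1 to compound 3 (within the scatter) and no change at the digits printed from compound 2 to compound 3 (within the scatter). All three have no size at the digits shown. Among the measured compounds shown here, the new ring does carry a methyl group, which none of the measured rings has, so these steps are a guide and not a direct test.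

On this evidence, no step beyond the scatter is expected in this assay. The expected change is no change at the digits printed from compound 1 to compound 4 (within the scatter). Compound 4 is estimated at 100000 nM, with an expected range of 40000 nM to 120000 nM.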

Compound 4, concentration for 50% growth inhibition: 100000 nM
Estimate against measurement, compound 4: no gap at the digits printed; the measured number falls inside the stated range.
By their numbers in this assay, from the lowest: compounds 1, 2, 3 and 4 (each within the scatter of the next).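

In this assay there is no change at the digits printed from compound 1 to compound 4 (within the scatter) and no change at the digits printed from compound 3 to compound 4 (within the scatter) and also no change at the digits printed from compound 2 to compound 4 (within the scatter). Compound 4 therefore extends the flat picture at this place on the carbonyl carbon to 1-methyl-1H-pyrazol-5-yl, a ring with more heavy atoms and more hydrogen-bond acceptors than furan-3-yl, and one that carries a methyl group, which none of the earlier rings has. No measurement shown here offers an explanation for this sameness.

As far as these compounds go, it remains open whether anything other than a five-membered aromatic ring at this place, such as a phenyl ring, an amine or a carboxylic acid, would move the number. From the compounds shown here alone, it is also open whether a shorter chain leading to the amide, or a change to the shared core, would matter more than the choice of ring.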